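The compounds below may be only part of what the source reports. "The series", "measured", "known", "first", "only" and "open" are said of these compounds alone.

Of the compounds shown here, three sharing one core have been measured in an in vitro ADME assay on microsomes from Gut (Homo sapiens) for metabolic stability, in the presence of a further agent that is not named here (a lower number here means slower removal, a higher number faster removal of the compound), so far. Compound 1 (`COc1ccc(Br)cc1Cn1c(C(=O)NCC(C)(C)CO)cc2cc(C#N)ccc21`) gives 94 mL.min-1.g-1 and compound 2 (`Cc1ccc(C(F)(F)F)cc1Cn1c(C(=O)NCC(C)(C)CO)cc2cc(C#N)ccc21`) gives 102 mL.min-1.g-1 while compound 3 (`Cc1ccc(Cl)cc1Cn1c(C(=O)NCC(C)(C)CO)cc2cc(C#N)ccc21`) gives 124 mL.min-1.g-1 as its intrinsic clearance in microsomes. Compound 3 therefore stands level with the other two, its gaps to both lying within the scatter. Compound 4 (`Cc1ccc(C)c(Cn2c(C(=O)NCC(C)(C)CO)cc3cc(C#N)ccc32)c1`) carries methyl in place of chloro on an aromatic carbon of compound 3 (methyl in place of chloro on an aromatic carbon), which turns 5-chloro-2-methylphenyl into 2,5-dimethylphenyl. Going by the values given here, no compound with methyl on that carbon has been measured, so the replacement itself remains untested. Among the compounds with values here, two measured steps bear on it. The closer one is chloro in place of trifluoromethyl on the same carbon, which amounts to a 1.2-fold higher number from compound 2 to compound 3 (0.08 log units; within the scatter) and lies within the scatter. The other is 5-chloro-2-methylphenyl in place of 5-bromo-2-methoxyphenyl, which amounts to a 1.3-fold higher number from compound 1 to compound 3 (0.12 log units; within the scatter) and also lies within the scatter. On that evidence, no step beyond the scatter is expected in this assay and no direction can be favoured. The estimated change is a 1.1-fold lower number from compound 3 to compound 4 (0.03 log units; within the scatter) and it is expected to stay within the scatter. For compound 4 the expected value is 115 mL.min-1.g-1 with an estimated range from 70 mL.min-1.g-1 to 190 mL.min-1.g-1 in this read-out.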

Compound 4, intrinsic clearance in microsomes: 124 mL.min-1.g-1
Estimate against measurement, compound 4: 1.1-fold (0.03 log units) below, within the range that was stated.
By their numbers in this assay, from the lowest: compounds 1, 2, 3 and 4 (each within the scatter of the next).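

At this carbon of the aromatic ring, para to a methyl group, methyl is now read directly in this assay, and the change from chloro gives no change at the digits printed from compound 3 to compound 4 (within the scatter), so the two groups cannot be told apart here. With a 1.2-fold higher number from compound 2 to compound 4 (0.08 log units; within the scatter), trifluoromethyl, chloro and methyl on this carbon all stand within the scatter of one another, which makes this the first sign that a carbon-only group here behaves no differently from the two halogen-bearing ones in this read-out, though no supporting measurement bears on the result. The wider change gives a 1.3-fold higher number from compound 1 to compound 4 (0.12 log units; within the scatter), so 2,5-dimethylphenyl also stands level with 5-bromo-2-methoxyphenyl, and none of the four compounds separates from the others.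

On these data alone, whether an amine or a carboxylic acid on this carbon would shift intrinsic clearance beyond the scatter remains open. Also open, as far as these compounds go, is what the methyl and methoxy groups contribute on their own, since compound 1 differs from the others in two places on the ring, and whether changing the nitrile or the amide chain of the shared core would matter more.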